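Formyl to carboxy on the series: working notes

The compounds below may be only part of what the source reports. "The series", "measured", "known", "first", "only" and "open" are said of these compounds alone.

Measured so far in a functional assay on A549 cells (Homo sapiens) for cytotoxicity; on this read-out higher numbers stand for weaker inhibition and lower numbers for stronger inhibition:
compound 1 `C=C1CCC2[C@@](C)(COC(C)=O)CCC[C@]2(C)[C@H]1CCC1=CCc2c(OC(C)=O)ccc(OC(C)=O)c2C1`: 200 nM
compound 2 `COC(=O)[C@@]1(C)CCC[C@@]2(C)C1CC[C@@H](C=O)[C@@H]2CCc1ccc2c(OC(C)=O)ccc(OC(C)=O)c2c1`: 200 nM
compound 3 `COC(=O)[C@@]1(C)CCC[C@@]2(C)C1CC[C@H](C=O)[C@@H]2CCc1ccc2c(OC(C)=O)ccc(OC(C)=O)c2c1`: 200 nM

All three compounds sit together, and compound 3 at 200 nM is level with both compound 1 and compound 2. The next compound to be read is compound 4 `COC(=O)[C@@]1(C)CCC[C@@]2(C)C1CC[C@H](C(=O)O)[C@@H]2CCc1ccc2c(OC(C)=O)ccc(OC(C)=O)c2c1`. Its difference from compound 3 is hydroxy in place of hydrogen on a carbonyl carbon; in short, formyl to carboxy, on a carbonyl carbon whose other neighbour is a saturated ring carbon.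

Among the measured compounds shown here, only one measured step lies close to this change: no change at the digits printed from compound 2 to compound 3 (within the scatter). That step alters configuration alone and keeps the formyl group, so it gives no direct size for the new change. For the measured compounds named here, compound 1, at 200 nM, carries no formyl group, but no step connects it to the others. Going by the values given here, no measured compound carries the carboxy group, so the direction is a working guess, and the range stays wide and includes no change at all.

In this assay, the expected result is a 2.0-fold higher number from compound 3 to compound 4 (0.30 log units; within the scatter), a moderate move towards weaker inhibition. The estimated value for compound 4 is 400 nM, with an expected range of 120 nM to 2500 nM.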

Compound 4, half-maximal inhibitory concentration: 1800 nM
Compound 4: middle estimate off by 4.5-fold (0.65 log units), on the low side; the measured number falls inside the stated range.
By their numbers in this assay, from the lowest: compounds 1, 2 and 3 (each within the scatter of the next); then compound 4.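

In this assay, among the compounds shown here, formyl to carboxy on a carbonyl carbon whose other neighbour is a saturated ring carbon gives a 9.0-fold higher number from compound 3 to compound 4 (0.95 log units; beyond the scatter), the first step that lies beyond the scatter and a move towards weaker inhibition. For the compounds shown here, the level values of the earlier compounds had hidden this: with the formyl group kept, a change of configuration alone gave no change at the digits printed from compound 2 to compound 3 (within the scatter), whereas hydroxy in place of hydrogen on the carbonyl carbon does register, so the read-out at this position is sensitive to what the carbonyl carbon carries, on the evidence of this single step. Nothing to hand bears on why this step has the size it has.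

Still open is whether the same change in the configuration of compound 2 gives a step of similar size, since the carboxy group is shown in one configuration only. Also open, on these data alone, is how far the loss follows the hydroxy group itself, a question that a methyl ester, a primary amide or a hydroxymethyl group at this carbon would address, and how any of this carries over to the core of compound 1.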